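A few compounds are considered here, and "the series" means these few. Any claim that something is new, unique, unknown or untested is made for them only; others in the source may bear on it.

In an ADME assay on MDBK cells (Bos taurus) for cytotoxicity (on this read-out higher numbers stand for lower toxicity in this test and lower numbers for higher toxicity in this test), compound 1 `Clc1ccc(Cn2ccc3nc(-c4ccccc4)nc-3c2)cc1` gives > 100000 nM, which is a limit of the assay and not a number. Compound 2 `FC(F)(F)c1ccc(Cn2ccc3nc(-c4ccccc4)nc-3c2)cc1` gives 84000 nM. Compound 3 `FC(F)(F)Oc1ccc(Cn2ccc3nc(-c4ccccc4)nc-3c2)cc1` gives 66000 nM, within the scatter of compound 2. Compound 4 `O=C(O)c1ccc(Cn2ccc3nc(-c4ccccc4)nc-3c2)cc1` differs from compound 3 as follows: carboxy in place of trifluoromethoxy on an aromatic carbon. This puts carboxy in place of trifluoromethoxy on an aromatic carbon, para to a large group. The measured steps at this place are an at least 1.1-fold lower number from compound 1 to compound 2 (0.07 log units; that floor lies within the scatter), an at least 1.5-fold lower number from compound 1 to compound 3 (0.18 log units; that floor lies within the scatter) and a 1.3-fold lower number from compound 2 to compound 3 (0.10 log units; within the scatter), and none is shown beyond the scatter. None of them introduces carboxy, but on these steps no change beyond the scatter is expected in this assay. The expected step is a 1.3-fold higher number from compound 3 to compound 4 (0.11 log units; within the scatter). Compound 4 is estimated at 85000 nM, with an expected range of 45000 nM to 160000 nM.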

Compound 4, half-maximal cytotoxic concentration: > 100000 nM
Compound 4: no number, only a limit (the forecaster's own chance of this, stated with the estimate: 50%); middle value at least 1.1-fold (0.07 log units) away from the limit.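

In this assay compound 4 gives > 100000 nM, a limit and not a number. Going by these compounds alone, the steps are an at least 1.5-fold higher number from compound 3 to compound 4 (0.18 log units; that floor lies within the scatter) and an at least 1.1-fold higher number from compound 2 to compound 4 (0.07 log units; that floor lies within the scatter), so carboxy, the first group here with a hydrogen-bond donor, brings no lower number at this position, while the step between compound 1 and compound 4 cannot be read. The top of the read-out now holds a second compound: the limit of > 100000 nM in this assay, at which 2 of the 4 values shown sit.

On these data alone, the true values of compound 1 and compound 4 stay open, so chloro and carboxy cannot be ordered. Whether an amine or an amide at this place also stays at the limit is open too.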